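Aryl amide variation on the shared core

The source may report more compounds than this note shows. Statements on the series, on what has been measured and on what is new or still open speak of the compounds shown alone.

Among the measured compounds shown here, compound 2 `O=C(CCC(=O)OCCCCCCSc1ccc([N+](=O)[O-])c2nonc12)Nc1ccc(C(F)(F)F)cc1` gives 4020 nM in a functional assay on A549 cells (Homo sapiens) for inhibition, read by MTT assay, with a stated time of 72 h (a higher number here means a weaker inhibitor, a lower number a stronger inhibitor), the higher of the two numbers measured so far, though its only neighbour, compound 1 `O=C(CCC(=O)OCCCCCCSc1ccc([N+](=O)[O-])c2nonc12)Nc1ccccc1F`, sits within the scatter of it; compound 1 gives 2440 nM in this assay. For the measured compounds named here, the single measured step, a 1.6-fold higher number from compound 1 to compound 2 (0.22 log units; within the scatter), comes from exchanging one aryl group for another on the amide nitrogen. Compound 3 `COc1ccc(NC(=O)CCC(=O)OCCCCCCSc2ccc([N+](=O)[O-])c3nonc23)cc1OC` is not yet measured and differs from compound 2 by 3,4-dimethoxyphenyl in place of 4-(trifluoromethyl)phenyl on an amide-type nitrogen. Going by the values given here, no measured step involves a dimethoxyphenyl group, so the one step in hand bears on it only loosely: a swap of aryl substituents on the amide nitrogen left the number within the scatter. On that basis no step beyond the scatter is expected in this assay, an expected 1.2-fold lower number from compound 2 to compound 3 (0.09 log units; within the scatter). Compound 3 is therefore estimated at 3300 nM in this assay, with a range from 1400 nM to 8000 nM.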

Compound 3, half-maximal inhibitory concentration: 3890 nM
The estimate for compound 3 lay 1.2-fold (0.07 log units) below the measured number, and the stated range covers the measured number.
By their numbers in this assay, from the lowest: compounds 1, 3 and 2 (each within the scatter of the next).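

In this assay, the step of a 1.0-fold lower number from compound 2 to compound 3 (0.01 log units; within the scatter) and the step of a 1.6-fold higher number from compound 1 to compound 3 (0.20 log units; within the scatter) both stay within the scatter. This extends the earlier picture at the amide-type nitrogen: 3,4-dimethoxyphenyl, which carries 2 hydrogen-bond acceptors and oxygen where 4-(trifluoromethyl)phenyl carries 0 and fluorine, also leaves the number within the scatter, so all three aryl groups shown at this position are indistinguishable in this read-out. No evidence on the reason for this result is at hand.

As far as these compounds go, whether a group of another kind on this nitrogen, such as a phenyl ring carrying a carboxylic acid or an aliphatic amine, would give a step beyond the scatter stays open. From the compounds shown here alone, the effect of changes away from this nitrogen, such as a longer chain in the linker, also stays open.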